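Series notes: removing the methylsulfonyl group in this assay

A few compounds are considered here, and "the series" means these few. Any claim that something is new, unique, unknown or untested is made for them only; others in the source may bear on it.

Measured so far:
compound 1 `CS(=O)(=O)c1ccc(-c2cnc3[nH]cc(-c4nnc(-c5ccccc5)o4)c(=O)c3c2)cc1`; in a functional assay on KB cells (Homo sapiens) for inhibition, read by MTT assay, with a stated time of 24 h, tested at 5 uM (on this read-out higher numbers stand for more inhibition of growth at the one concentration tested and lower numbers for less inhibition of growth), compound 1 gives 4.38%
compound 2 `CS(=O)(=O)c1ccc(-c2cnc3[nH]cc(-c4nnc(-c5ccc(Cl)cc5)o4)c(=O)c3c2)cc1`; compound 2 gives 2.15%
compound 3 `Cc1ccc(-c2nnc(-c3c[nH]c4ncc(-c5ccc(S(C)(=O)=O)cc5)cc4c3=O)o2)cc1`; compound 3 gives 0.43%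

Compound 2 stands second highest of the three numbers, but the spread is negligible: nearest is compound 3, a number 1.7 percentage points lower from compound 2 to compound 3 (within the scatter), furthest is compound 1, a number 2.2 percentage points lower from compound 1 to compound 2 (within the scatter), and likewise a number 4 percentage points lower from compound 1 to compound 3 (within the scatter). All three compounds sit near zero in this assay and cannot be told apart.

Compound 4 `O=c1c(-c2nnc(-c3ccc(Cl)cc3)o2)c[nH]c2ncc(-c3ccccc3)cc12` differs from compound 2 in one place: hydrogen in place of methylsulfonyl on an aromatic carbon. Going by the values given here, none of the measured steps bears on this change; each of them varies the other aromatic ring (chloro, methyl, hydrogen) and each stayed within the scatter. Among the compounds with values here, there is therefore no measured guidance for the methylsulfonyl position, only the observation that every member of the series so far gives essentially no growth inhibition. The expectation for compound 4 is accordingly no step beyond the scatter, a number 0.9 percentage points higher from compound 2 to compound 4 (within the scatter). Compound 4 is estimated at 3%, with a range of -7% to 13%.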

Compound 4, percent growth inhibition at one concentration: 2.15%
The estimate for compound 4 lay 0.9 percentage points above the measured number; the range from low to high includes it.
By their numbers in this assay, from the lowest: compounds 3, 2, 4 and 1 (each within the scatter of the next).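

In this assay, replacing methylsulfonyl with hydrogen on the aromatic carbon gives no change at the digits printed from compound 2 to compound 4 (within the scatter). Going by these compounds alone, this is the first reading at this position, as the earlier steps varied only the other aromatic ring. Losing all four heavy atoms of the group does not bring growth inhibition into view, and compound 4 stays near zero with the rest of the series. No measurement shown gives a reason for this result.

On these data alone, with every number near zero at a single concentration, it remains open whether this position matters at all in a compound with clear growth inhibition. Also open, as far as these compounds go, is whether an amine or a carboxylic acid in place of methylsulfonyl would give a step beyond the scatter.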